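This account rests on a few compounds, and the source may have more. Where it says the series, first, only, none or still open, it means among the compounds named here.

Compound 3 `O=S(=O)(Nc1ccc2oc(-c3ccccc3)nc2c1)c1ccc(O)cc1` stands at the limit of an assay on isolated protein for inhibition of malate dehydrogenase, mitochondrial (Sus scrofa), with stated times of 45 min and 30 min; on this read-out higher numbers stand for weaker inhibition and lower numbers for stronger inhibition: in this assay compound 3 gives > 63000 nM, which is a limit rather than a number. Compound 1 `O=S(=O)(Nc1ccc2oc(-c3ccccc3)nc2c1)c1ccc(Cl)c(Cl)c1` gives > 63000 nM, also a limit. Compound 2 `O=S(=O)(Nc1ccc2oc(-c3ccccc3)nc2c1)c1cccc(C(F)(F)F)c1` gives > 63000 nM, again a limit. Compound 4 `O=S(=O)(Nc1ccc2oc(-c3ccccc3)nc2c1)c1cccc(O)c1` has not been measured; it differs from compound 3 by 3-hydroxyphenyl in place of 4-hydroxyphenyl on a sulfonyl sulfur. For the measured compounds named here, the one measured step at the same position is a step that the two limits leave unreadable from compound 1 to compound 3, and it is unreadable, as the limit of > 63000 nM in this assay, at which 3 of the 3 values shown sit, shows, with both ends at a limit. With every measured value at a limit, the step that the limit leaves unreadable from compound 3 to compound 4 is expected to be none beyond the scatter, most likely leaving compound 4 at a limit as well. Compound 4 is therefore estimated at 100000 nM, with a range from 40000 nM to 300000 nM.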

Compound 4, half-maximal inhibitory concentration: > 63000 nM
Compound 4 gave a limit, no number; the forecaster's own chance of this, stated with the estimate: 85%; the middle value does not contradict the limit.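

Compound 4 behaves like compound 1, compound 2 and compound 3, so no step among these compounds can be read: the limit of > 63000 nM in this assay, at which 4 of the 4 values shown sit. Going by these compounds, how strongly any of them inhibits, and whether 3-hydroxyphenyl and 4-hydroxyphenyl differ at all, stays open.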